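Phenyl in Place of tert-Butyl on a Second Core

This account rests on a few compounds, and the source may have more. Where it says the series, first, only, none or still open, it means among the compounds named here.

In a functional assay on a cell-free system (plasma, Homo sapiens), with a stated time of 3 min (on this read-out higher numbers stand for weaker inhibition and lower numbers for stronger inhibition), compound 1 `CC(C)(C)[C@@H](O)C(=O)N1C[C@@H]2C[C@@H]2[C@H]1C(=O)NCc1cc(Cl)ccc1-n1cnnn1` gives 570 nM. Compound 3 `O=C(NCc1cc(Cl)ccc1-n1cnnn1)[C@@H]1[C@H]2C[C@H]2CN1C(=O)[C@H](O)c1ccccc1` differs from it in one place, (phenyl in place of tert-butyl on a saturated chain carbon bound to a carbonyl carbon and an oxygen on a saturated carbon), and in this assay compound 3 gives 960 nM; the step is a 1.7-fold higher number from compound 1 to compound 3 (0.23 log units; within the scatter). Compound 2 `CC(C)(C)[C@@H](O)C(=O)N1OCC[C@H]1C(=O)NCc1cc(Cl)ccc1-n1cnnn1` rests on a different core, and how its core differs from that of compound 1 is not broken down here. In this assay compound 2 gives 1600 nM, which lies beyond the scatter from compound 1 and within the scatter of compound 3. Compound 4 `O=C(NCc1cc(Cl)ccc1-n1cnnn1)[C@@H]1CCON1C(=O)[C@H](O)c1ccccc1` has not yet been measured. It carries the same change on the core of compound 2: phenyl in place of tert-butyl on a saturated chain carbon bound to a carbonyl carbon and an oxygen on a saturated carbon. The place of the change is the same in both pairs, so it is the same change made twice. For the measured compounds named here, for compound 4 the expected step is a 1.7-fold higher number from compound 2 to compound 4 (0.23 log units; within the scatter), because the one earlier instance of this change gave a 1.7-fold higher number from compound 1 to compound 3 (0.23 log units; within the scatter). On that basis compound 4 is estimated at 2700 nM in this assay, with a range from 1300 nM to 5600 nM.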

Compound 4, half-maximal inhibitory concentration: 1500 nM
The estimate for compound 4 lay 1.8-fold (0.26 log units) above the measured number; the range from low to high includes it.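

On the core of compound 2, phenyl in place of tert-butyl gives a 1.1-fold lower number from compound 2 to compound 4 (0.03 log units; within the scatter), so in this assay compound 2 and compound 4 cannot be told apart. Set beside the earlier instance on the core of compound 1, the new step agrees with it, and the change shows no dependence on the core: the same change on two cores in this assay, a 1.7-fold higher number (0.23 log units; within the scatter) from compound 1 to compound 3 and a 1.1-fold lower number (0.03 log units; within the scatter) from compound 2 to compound 4, 1.8-fold (0.25 log units) apart, within the scatter of two such steps On these two cores, then, phenyl and tert-butyl at this place are interchangeable within the scatter, but two pairs do not show that this would hold on a further core, and they do not explain why the two groups read alike.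

Only tert-butyl and phenyl stand at this place in the compounds shown, so it remains open how a cyclohexyl group or a pyridine ring would read there on either core. Equally open, on these data alone, is what an amine in place of the hydroxy group on that carbon would do to either pair.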